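The compounds below may be only part of what the source reports. "The series", "measured", "known", "first", "only" and "open" are said of these compounds alone.

Within the data shown here, only two compounds sharing one core have been tested so far in a functional assay on K562 cells (Homo sapiens), read by MTT assay, with a stated time of 72 h; a higher number here means a weaker inhibitor, a lower number a stronger inhibitor. The first is compound 1 `COc1ncnc2c1c(-c1cc3ccccc3o1)cn2[C@@H]1O[C@H](CO)[C@@H](O)[C@H]1O`, and the second is compound 2 `CN(C)c1ncnc2c1c(-c1ccsc1)cn2[C@@H]1O[C@H](CO)[C@@H](O)[C@H]1O`. In this test, compound 2 gives > 20000 nM. That entry is a limit of the assay and not a number, so compound 2 has no exact position on the scale.

The next compound, compound 3 `CN(C)c1ncnc2c1c(-c1cc3ccccc3o1)cn2[C@@H]1O[C@H](CO)[C@@H](O)[C@H]1O`, keeps the rest of compound 2 and changes one group: 1-benzofuran-2-yl takes the place of thiophen-3-yl on an aromatic carbon (1-benzofuran-2-yl in place of thiophen-3-yl on an aromatic carbon). Among the measured compounds shown here, no measured pair shows this exchange on its own, so any forecast is loose. For the measured compounds named here, the only guide is compound 1, which also carries the 1-benzofuran-2-yl group and gives 13100 nM in this assay. On that basis, a modest move towards stronger inhibition, meaning a lower number, is expected, and the estimated step is an at least 1.3-fold lower number from compound 2 to compound 3 (0.12 log units; that floor lies within the scatter). A result that again reaches only the limit would not be surprising. For compound 3 the expected value is 15000 nM, within an estimated range of 5000 nM to 30000 nM.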

Compound 3, half-maximal inhibitory concentration: > 20000 nM
Compound 3 ended at the assay's limit; the forecaster's own chance of this, stated with the estimate: 45%; middle value at least 1.3-fold (0.12 log units) away from the limit.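

With dimethylamino held in place, putting the fused 1-benzofuran-2-yl on this aromatic carbon instead of thiophen-3-yl does not bring the compound into the readable range of this assay, and the size of that step cannot be read because both compounds stop at a limit of the assay, which is not a number: the limit of > 20000 nM in this assay, at which 2 of the 3 values shown sit.

Among these compounds, the only readable step comes from the other point of change, dimethylamino in place of methoxy on an aromatic carbon with 1-benzofuran-2-yl kept, and it is an at least 1.5-fold higher number from compound 1 to compound 3 (0.18 log units; that floor lies within the scatter). Since that floor lies within the scatter, the step alone does not establish a real difference between the two groups. Among the compounds shown here, compound 1, at 13100 nM, remains the only compound here with an exact value.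

The compounds shown leave open whether methoxy combined with thiophen-3-yl would give a readable value, which would allow the two aromatic groups to be compared directly. They also leave open whether a plain phenyl ring, or a ring carrying a carboxylic acid or an amine, on the same aromatic carbon would lower the number in this assay.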